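Losing the diethylamino chain on the amide nitrogen

The source may report more compounds than this note shows. Statements on the series, on what has been measured and on what is new or still open speak of the compounds shown alone.

Measured so far in a functional assay on BXPC-3 cells (Homo sapiens) for antiproliferative activity, read by MTT assay, with a stated time of 24 h; a higher number here means a weaker inhibitor, a lower number a stronger inhibitor:
- compound 1 `CCn1c(C(=O)NCCNC(=O)OC(C)(C)C)ccc1C(CC)(CC)c1ccc(OCS(=O)(=O)c2ccccc2)c(C)c1`: > 50000 nM (a limit)
- compound 2 `CCN(CC)CCNC(=O)c1ccc(C(CC)(CC)c2ccc(OCS(=O)(=O)c3ccccc3)c(C)c2)n1CC`: 6270 nM

Within the data shown here, compound 2 gives 6270 nM, the only true number so far. For compound 1 there is only a limit (the limit of > 50000 nM in this assay, at which 1 of the 2 values shown sits). Among the measured compounds shown here, the one measured step is an at least 7.9-fold lower number from compound 1 to compound 2 (0.90 log units; beyond the scatter), with diethylamino in place of (tert-butoxycarbonyl)amino on a saturated chain carbon.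

Compound 3 `CCn1c(C(=O)N[C@@H](C)CO)ccc1C(CC)(CC)c1ccc(OCS(=O)(=O)c2ccccc2)c(C)c1` carries 1-(hydroxymethyl)ethyl in place of 2-(diethylamino)ethyl on an amide-type nitrogen. Like compound 1, it has no diethylamino group, and that group is what separates compound 2 from compound 1 in the step of an at least 7.9-fold lower number from compound 1 to compound 2 (0.90 log units; beyond the scatter). For the measured compounds named here, this single step is the only guide, and it comes from a different replacement, so its size carries over only loosely. A move to a higher number in this assay, beyond the scatter, is therefore expected. The expected step is a 4.0-fold higher number from compound 2 to compound 3 (0.60 log units; beyond the scatter). For compound 3 the estimated value is 25000 nM, with an expected range of 9000 nM to 60000 nM, and a result reported only as a limit would be no surprise.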

Compound 3, half-maximal inhibitory concentration: 15300 nM
For compound 3 the middle estimate is 1.6-fold (0.21 log units) above the measured one, and the stated range covers the measured number.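

In this assay, losing the diethylamino group from the amide-type nitrogen does not by itself take the compound out of the measurable range, and 1-(hydroxymethyl)ethyl in place of 2-(diethylamino)ethyl gives a 2.4-fold higher number from compound 2 to compound 3 (0.39 log units; beyond the scatter). Even so, the diethylamino chain of compound 2 keeps the lowest number of the three compounds, while compound 3, which also lacks that group, still improves on the Boc-protected chain with an at least 3.2-fold lower number from compound 1 to compound 3 (0.51 log units; beyond the scatter), so the outcome at this nitrogen depends on more than the presence or absence of diethylamino. The last step is open-ended, as the value of compound 1 is only a limit: the limit of > 50000 nM in this assay, at which 1 of the 3 values shown sits.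

Among these compounds, the single change at compound 3 swaps the whole chain, so the hydroxyl group, the branching and the defined stereocentre of 1-(hydroxymethyl)ethyl cannot be told apart, and the mirror-image chain or an unbranched 2-hydroxyethyl chain would separate them. As far as these compounds go, it also remains open whether another amine on the ethyl chain, such as dimethylamino, morpholine or piperidine, would match or pass compound 2, or whether a longer chain carrying diethylamino would do so.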